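The source may hold more compounds than are shown below. What is called first, only, known or untested is meant among the compounds shown, and "the series" means these compounds.

Compound 1 `CC1=CC[C@H](C(C)(C)NC(=S)NN)CC1` is the simplest of the three measured compounds. In a functional assay on NCI-H460 cells (Homo sapiens) for inhibition, read by sulforhodamine B assay, with a stated time of 48 h (a higher number here means a weaker inhibitor of growth, a lower number a stronger inhibitor of growth), compound 1 gives 42000 nM. Compound 2 `COc1ccc(/C=N/NC(=S)NC(C)(C)[C@H]2CC=C(C)CC2)cc1` carries a 4-methoxyphenyl on a carbon with a double bond to nitrogen, and in this assay compound 2 gives 22500 nM. Among the compounds with values here, compound 3 `CC1=CC[C@H](C(C)(C)NC(=S)N/N=C/c2cccc(Cl)c2)CC1` carries a 3-chlorophenyl in that place instead, and in this assay compound 3 gives 1400 nM, the lowest of the three numbers; the step of a 16-fold lower number from compound 2 to compound 3 (1.21 log units; beyond the scatter) is the only one-change step among the measured compounds. Compound 4 `CC1=CC[C@H](C(C)(C)NC(=S)N/N=C/c2ccc[nH]2)CC1` is not yet measured; it differs from compound 3 by 1H-pyrrol-2-yl in place of 3-chlorophenyl on a carbon with a double bond to nitrogen. Within the data shown here, no measured step exchanges a six-membered ring for a five-membered one, so there is no direct guide. Because the step of a 16-fold lower number from compound 2 to compound 3 (1.21 log units; beyond the scatter) was large, a change in this place is expected to move the number again, and with compound 1 far higher still, the 1H-pyrrol-2-yl is expected to bring a step of a 5.7-fold higher number from compound 3 to compound 4 (0.76 log units; beyond the scatter) towards weaker inhibition. For compound 4 in this assay the expected value is 8000 nM, with a range from 2000 nM to 30000 nM.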

Compound 4, concentration for 50% growth inhibition: 18000 nM
Beside the measured number, compound 4's estimate is 2.3-fold (0.35 log units) below it, within the range that was stated.
By their numbers in this assay, from the lowest: compound 3; then compounds 4, 2 and 1 (each within the scatter of the next, the first and the last beyond it).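

Putting 1H-pyrrol-2-yl in place of 3-chlorophenyl gives a 13-fold higher number from compound 3 to compound 4 (1.11 log units; beyond the scatter) in this assay, so an aromatic ring at this place does not by itself bring the low number of compound 3. Exchanging the 4-methoxyphenyl for the same five-membered ring gives a 1.3-fold lower number from compound 2 to compound 4 (0.10 log units; within the scatter), so these two groups cannot be told apart here, and among the three rings shown only the 3-chlorophenyl stands apart. The 1H-pyrrol-2-yl still keeps a modest advantage over the unsubstituted end of compound 1, seen as a 2.3-fold lower number from compound 1 to compound 4 (0.37 log units; beyond the scatter) and far smaller than the distance reached by compound 3.

As far as these compounds go, it remains open how a pyridine ring, a carboxylic acid or a longer chain would read at this place. No evidence here explains why the 3-chlorophenyl stands apart.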